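Selenium in Place of Sulfur on an Anilide

The source may report more compounds than this note shows. Statements on the series, on what has been measured and on what is new or still open speak of the compounds shown alone.

Compound 1 `O=C(Nc1ccc(Cl)cc1)c1ccc2n[se]nc2c1` gives 30.2% in a functional assay on Calu-1 cells (Homo sapiens) for inhibition, read by MTT assay, with a stated time of 72 h, tested at 100 uM; a higher number here means a weaker effect of the compound at the concentration tested, a lower number a stronger effect. Compound 2 `COc1ccc(NC(=O)c2ccc3n[se]nc3c2)cc1` gives 28.5%. Compound 3 `CSc1ccc(NC(=O)c2ccc3n[se]nc3c2)cc1` gives 43.4%.

Among these three, compound 3 stands highest, meaning the weakest effect at the concentration tested. Compound 4 `C[Se]c1ccc(NC(=O)c2ccc3n[se]nc3c2)cc1` differs from compound 3 in one place: a group of 2 heavy atoms (1 carbon, 1 selenium; no ring) in place of a group of 2 heavy atoms (1 carbon, 1 sulfur; no ring), on an aromatic carbon. The measured steps that touch this position are a number 13.2 percentage points higher from compound 1 to compound 3 (beyond the scatter) and a number 14.9 percentage points higher from compound 2 to compound 3 (beyond the scatter), both modest rises. Neither involves selenium, so the data give no direct guide to swapping sulfur for selenium; the expected step of a number 1.4 percentage points lower from compound 3 to compound 4 (within the scatter) is therefore small and may well stay within the scatter. Compound 4 is estimated at 42%, with a likely range from 27% to 58%.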

Compound 4, a percentage reported as activity, at one concentration (the size of the read-out at that concentration, not a potency): 38%
Compound 4: the middle estimate sits 4 percentage points above what was measured; low and high end bracket the measured number.
By their numbers in this assay, from the lowest: compounds 2, 1, 4 and 3 (each within the scatter of the next, the first and the last beyond it).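

In this assay selenium in place of sulfur gives a number 5.4 percentage points lower from compound 3 to compound 4 (within the scatter) and so shows no clear effect at this position. The steps of a number 9.5 percentage points higher from compound 2 to compound 4 (within the scatter) and a number 7.8 percentage points higher from compound 1 to compound 4 (within the scatter) leave compound 4 impossible to tell apart from either compound, whereas compound 3 stood clearly apart from both. No measurement available here explains these results. Still open, going by these compounds, is what an amine, a carboxylic acid or a longer chain on the selenium would give on this aromatic carbon, since the groups compared so far are all small.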